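A few compounds are considered here, and "the series" means these few. Any claim that something is new, unique, unknown or untested is made for them only; others in the source may bear on it.

Measured in a functional assay on Shh Light II cells (Mus musculus) for inhibition, read by a luciferase reporter; a lower number here means a stronger inhibitor, a higher number a weaker inhibitor:
- compound 1 `O=C(N1CCC(c2nc(-c3ccc4ccccc4n3)no2)CC1)N1CCCc2ccccc21`: 2300 nM
- compound 2 `O=C(NC1CCC(O)CC1)N1CCC(c2nc(-c3ccc4ccccc4n3)no2)CC1`: 2700 nM
- compound 3 `N#Cc1ccccc1NC(=O)N1CCC(c2nc(-c3ccc4ccccc4n3)no2)CC1`: 190 nM

Compound 3 has the lowest number of the three, making it the strongest inhibitor in this small set. The measured steps to it are a 12-fold lower number from compound 1 to compound 3 (1.08 log units; beyond the scatter) and a 14-fold lower number from compound 2 to compound 3 (1.15 log units; beyond the scatter), both large, while a 1.2-fold higher number from compound 1 to compound 2 (0.07 log units; within the scatter) stays within the scatter. Those large steps replace the whole group on the carbonyl carbon, so none of them tests the cyano alone.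

Compound 4 `O=C(Nc1ccccc1C(F)(F)F)N1CCC(c2nc(-c3ccc4ccccc4n3)no2)CC1` keeps the rest of compound 3 and has trifluoromethyl in place of cyano on an aromatic carbon, ortho to a large group: trifluoromethyl in place of cyano on an aromatic carbon. For the measured compounds named here, no measured pair tests this swap, so the large steps set no size for it. Compound 4 does retain a substituted phenylamino group, as does compound 3 at 190 nM, so it is expected to stay nearer that value than to the other two in this assay. The expected change is small, perhaps slightly weaker and probably within the scatter: a 1.3-fold higher number from compound 3 to compound 4 (0.12 log units; within the scatter). For compound 4 the estimated value is 250 nM, with an expected range of 80 nM to 800 nM.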

Compound 4, half-maximal inhibitory concentration: 700 nM
Beside the measured number, compound 4's estimate is 2.8-fold (0.45 log units) below it; low and high end bracket the measured number.
By their numbers in this assay, from the lowest: compound 3; then compound 4; then compounds 1 and 2 (each within the scatter of the next).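

In this assay, for the compounds shown here, this is the first step that changes only the group on this aromatic carbon, with the rest of the molecule held fixed, and the swap is not neutral: a 3.7-fold higher number from compound 3 to compound 4 (0.57 log units; beyond the scatter). Going by these compounds alone, the group here therefore counts in its own right, which the earlier steps could not show, as they replaced the whole group on the carbonyl carbon. Some of the advantage of the substituted phenylamino group also survives without the nitrile, with a 3.9-fold lower number from compound 2 to compound 4 (0.59 log units; beyond the scatter) and a 3.3-fold lower number from compound 1 to compound 4 (0.52 log units; beyond the scatter); no measurement at hand explains why the two groups differ.

The compounds shown leave open how a plain phenyl with hydrogen at this carbon would compare, and how a chlorine atom or a methoxy group would read there. They also leave open whether the nitrile would give the same number from another carbon of the ring.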